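The compounds below may be only part of what the source reports. "The series", "measured", "known", "first", "only" and "open" are said of these compounds alone.

Measured compounds:
Compound 1, `Cc1cc(=O)oc2cc(SCc3ccccn3)ccc12`, in a functional assay on KBVIN cells (Homo sapiens) for antiproliferative activity, read by sulforhodamine B assay, with a stated time of 72 h (on this read-out lower numbers stand for stronger inhibition of growth and higher numbers for weaker inhibition of growth), gives > 35200 nM, which is a limit of the assay and not a number.
Compound 2, `Cc1cc(=O)oc2cc(SCc3cccnc3)ccc12`, in this assay gives > 35200 nM, again a limit of the assay rather than a number.
Compound 3, `COC(=O)c1cccc(CSc2ccc3c(C)cc(=O)oc3c2)c1`, in this assay gives 5410 nM.

Among the measured compounds shown here, compound 3 therefore stands as the only compound with a numerical result in this assay, since the other two values sit at the limit (the limit of > 35200 nM in this assay, at which 2 of the 3 values shown sit). For the measured compounds named here, the one step among the measured compounds, a step that the two limits leave unreadable from compound 1 to compound 2, runs between two limits and its size cannot be read, so it says nothing about the change now at hand.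

Compound 4, `Cc1cccc(CSc2ccc3c(C)cc(=O)oc3c2)c1`, differs from compound 3 by methyl in place of methoxycarbonyl on an aromatic carbon. Going by the values given here, no measured step touches this change, and compound 3 is the only anchor. The estimate for compound 4 therefore rests on compound 3 alone, and the expected step of a 1.7-fold higher number from compound 3 to compound 4 (0.22 log units; within the scatter) is set as a modest weakening that may not exceed the usual scatter. Compound 4 is thus expected to give about 9000 nM in this assay, with a range from 3000 nM to 35000 nM.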

Compound 4, concentration for 50% growth inhibition: > 33700 nM
Compound 4 gave a limit, no number (the forecaster's own chance of this, stated with the estimate: 30%); middle value at least 3.7-fold (0.57 log units) from the limit.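

Among the compounds shown here, replacing methoxycarbonyl with methyl on this aromatic carbon, meta to a large group, gives an at least 6.2-fold higher number from compound 3 to compound 4 (0.79 log units; beyond the scatter) in this assay, so this is the first readable change and it shows that the result at this position depends on the group carried there. Compound 4 sits at a limit of the assay, which is not a number: the limit of > 33700 nM in this assay, at which 1 of the 4 values shown sits. The steps from compound 1 and from compound 2 to compound 4 run between limits and cannot be read, so 3-methylphenyl cannot be ranked against pyridin-2-yl or pyridin-3-yl.

The compounds shown leave open whether the number of compound 3 needs the methoxycarbonyl itself, or whether a carboxylic acid, a primary amide or a nitrile on the same carbon would serve as well. They also leave open how a plain hydrogen there would compare with methyl.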